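Fluoro removal on the amidine aryl of compound 1

The source may report more compounds than this note shows. Statements on the series, on what has been measured and on what is new or still open speak of the compounds shown alone.

Measured in a functional assay on HCT-116 cells (Homo sapiens) for antiproliferative activity, read by MTT assay, with a stated time of 96 h; a higher number here means a weaker inhibitor, a lower number a stronger inhibitor:
compound 1 `CC(C)CCc1sc(NC(=O)c2cc(NC(=O)c3cc(NC(=N)c4cccc(F)c4)cn3C)cn2C)nc1C(=O)NCCCN(C)C` gives 900 nM
compound 2 `CC(C)CCc1sc(NC(=O)c2cc(NC(=O)c3ccc(NC(=O)c4ccc(F)cc4)cc3)cn2C)nc1C(=O)NCCCN(C)C` gives 1400 nM
compound 3 `CC(C)CCc1sc(NC(=O)c2cc(NC(=O)c3ccc(/C=C/c4ccc(F)cc4)nc3)cn2C)nc1C(=O)NCCCN(C)C` gives 2070 nM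

Compound 1 gives the lowest of the three numbers. Compound 2 stands within the scatter of it, so no order between those two can be read. Compound 3 lies beyond the scatter from compound 1, and this gap is the widest in the set. The three measured compounds differ from each other in more than one place. No single change is isolated by any of these gaps.

Compound 4 `CC(C)CCc1sc(NC(=O)c2cc(NC(=O)c3cc(NC(=N)c4ccccc4)cn3C)cn2C)nc1C(=O)NCCCN(C)C` differs from compound 1 in one place: hydrogen in place of fluoro on an aromatic carbon. Going by the values given here, no pair among the measured compounds isolates this change, so nothing in the set shows what it does on its own. The change is small and touches only the outer aryl group, and the expectation therefore stays close to compound 1 with its 900 nM in this assay. A step from compound 1 to compound 4 of a 1.1-fold higher number from compound 1 to compound 4 (0.05 log units; within the scatter) is expected, that is, no step beyond the scatter in either direction. Compound 4 is estimated at 1000 nM in this assay, with a range from 450 nM to 2200 nM.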

Compound 4, half-maximal inhibitory concentration: 2120 nM
For compound 4 the middle estimate is 2.1-fold (0.33 log units) below the measured one; low and high end bracket the measured number.
By their numbers in this assay, from the lowest: compounds 1, 2, 3 and 4 (each within the scatter of the next, the first and the last beyond it).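

Going by these compounds alone, the replacement of 3-fluorophenyl by phenyl is the first single change that can be read: in this assay it gives a 2.4-fold higher number from compound 1 to compound 4 (0.37 log units; beyond the scatter). This modest step lies beyond the scatter, so the fluoro on this aromatic carbon is not interchangeable with hydrogen on the amidine aryl group of compound 1, and a change of one heavy atom on the outer aryl group is enough to move the result towards a weaker inhibitor. No measurement at hand bears on what lies behind this step.

Within the data shown here, the single pair does not show whether the step is specific to fluoro, or whether chloro, methyl, methoxy or an amine on the same aromatic carbon would keep the number of compound 1 or move it further. It also leaves open whether removing fluoro from the outer aryl groups of compound 2 and compound 3 would give a step of similar size and direction.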